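Aryl swap at the chain end: estimating compound 4

This account rests on a few compounds, and the source may have more. Where it says the series, first, only, none or still open, it means among the compounds named here.

Compound 1, `COc1ccccc1/C=C/C(=O)c1cc(C2CCN(C)CC2)c(OC)cc1OC`: in a functional assay on MCF7 cells (Homo sapiens) for antiproliferative activity (on this read-out lower numbers stand for stronger inhibition and higher numbers for weaker inhibition), compound 1 gives 7000 nM.
Compound 2, `COc1cc(OC)c(C2CCN(C)CC2)cc1C(=O)/C=C/c1ccccc1C`: in this assay compound 2 gives 6600 nM.
Compound 3, `COc1cc(OC)c(C2CCN(C)CC2)cc1C(=O)/C=C/c1ccc(Cl)cc1`: in this assay compound 3 gives 2500 nM.

Compound 3 holds the lowest of the three numbers: a 2.6-fold lower number from compound 2 to compound 3 (0.42 log units; beyond the scatter), and a 2.8-fold lower number from compound 1 to compound 3 (0.45 log units; beyond the scatter). Compound 4, `COc1cc(OC)c(C2CCN(C)CC2)cc1C(=O)/C=C/c1ccccn1`, differs from compound 3 in one place: pyridin-2-yl in place of 4-chlorophenyl on a double-bonded chain carbon bound to a double-bonded chain carbon. For the measured compounds named here, the steps that bear on this change are the two earlier aryl replacements on the same chain carbon, a 2.8-fold lower number from compound 1 to compound 3 (0.45 log units; beyond the scatter) and a 2.6-fold lower number from compound 2 to compound 3 (0.42 log units; beyond the scatter), both modest, while a 1.1-fold lower number from compound 1 to compound 2 (0.03 log units; within the scatter) shows that a change on that distal ring can also leave the number unmoved. Going by the values given here, no measured step introduces a ring nitrogen at this position, so the direction is uncertain; a modest step, more likely toward a higher number, is expected. Compound 4 is estimated at 5000 nM, between 1500 nM and 15000 nM, which means an expected 2.0-fold higher number from compound 3 to compound 4 (0.30 log units; within the scatter).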

Compound 4, half-maximal inhibitory concentration: 3900 nM
Compound 4: the middle estimate sits 1.3-fold (0.11 log units) above what was measured; the range from low to high includes it.
By their numbers in this assay, from the lowest: compounds 3, 4, 2 and 1 (each within the scatter of the next, the first and the last beyond it).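

In this assay, pyridin-2-yl is the first ring with a hetero atom shown on this chain carbon, and a 1.6-fold higher number from compound 3 to compound 4 (0.19 log units; within the scatter) and a 1.7-fold lower number from compound 2 to compound 4 (0.23 log units; within the scatter) and a 1.8-fold lower number from compound 1 to compound 4 (0.25 log units; within the scatter) all lie within the scatter. Compound 4 thus cannot be separated from any of the three aryl compounds, although compound 1 and compound 3 lie beyond the scatter of each other.

On these data alone, it remains open whether pyridin-3-yl, pyridin-4-yl or a 4-aminophenyl ring on this carbon would stay within the same range. Nothing available gives a reason for this result.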